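Carboxy to carbamoyl on the shared core

A few compounds are considered here, and "the series" means these few. Any claim that something is new, unique, unknown or untested is made for them only; others in the source may bear on it.

Measured compounds in a functional assay on Raji cells (Homo sapiens) for antiproliferative activity, read by CCK-8 assay, with a stated time of 72 h; a higher number here means a weaker inhibitor, a lower number a stronger inhibitor:
compound 1 `CN1CCN(c2ccc(Nc3nc(-c4cccc(NC(=O)c5ccccc5F)c4)sc3C(=O)O)cc2)CC1`: 13900 nM
compound 2 `CN1CCN(c2ccc(Nc3nc(-c4cccc(NC(=O)c5ccc(Cl)cc5)c4)sc3C(=O)O)cc2)CC1`: 7020 nM
compound 3 `CN1CCN(c2ccc(Nc3nc(-c4cccc(NC(=O)c5ccc(F)c(Cl)c5)c4)sc3C(=O)O)cc2)CC1`: 8740 nM

All three share the same core and differ only in the aryl group on the amide carbonyl. None of the steps among them leaves the scatter: a 2.0-fold lower number from compound 1 to compound 2 (0.30 log units; within the scatter), a 1.6-fold lower number from compound 1 to compound 3 (0.20 log units; within the scatter) and a 1.2-fold higher number from compound 2 to compound 3 (0.10 log units; within the scatter). Compound 3 therefore sits among numbers that cannot be told apart from one another.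

Compound 4 `CN1CCN(c2ccc(Nc3nc(-c4cccc(NC(=O)c5ccc(F)c(Cl)c5)c4)sc3C(N)=O)cc2)CC1` is not yet measured. The change from compound 3 is amino in place of hydroxy on a carbonyl carbon, which read one bond further out is carboxy to carbamoyl. Among the measured compounds shown here, no measured step touches this position; every step so far concerns the aryl group on the other carbonyl carbon, and all were within the scatter. There is no evidence from the series for a step in either direction, so no step beyond the scatter is expected in this assay, though the uncertainty is wide.

Compound 4 is estimated at 7000 nM, range 1500 nM to 30000 nM. The expected step is a 1.2-fold lower number from compound 3 to compound 4 (0.10 log units; within the scatter).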

Compound 4, half-maximal inhibitory concentration: 6230 nM
The estimate for compound 4 lay 1.1-fold (0.05 log units) above the measured number; the measured number falls inside the stated range.
By their numbers in this assay, from the lowest: compounds 4, 2, 3 and 1 (each within the scatter of the next, the first and the last beyond it).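

In this assay, among the compounds shown here, carboxy to carbamoyl gives a 1.4-fold lower number from compound 3 to compound 4 (0.15 log units; within the scatter), so the first change at this position, which none of the earlier aryl steps touched, also stays within the scatter. With the 3-chloro-4-fluorophenyl group held fixed, a free carboxy group is not needed to keep the number at this level, although this rests on a single pair. Nothing available bears on why hydroxy and amino on this carbonyl carbon read alike.

Still open, as far as these compounds go, is whether the same change reads alike with the 4-chlorophenyl or 2-fluorophenyl group on the other carbonyl carbon. Also open, from the compounds shown here alone, is how a methyl ester or a nitrile in place of the carboxy group would read, since only carboxy and carbamoyl appear at this position.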